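Triazole Aryl Variation in an Antiproliferative Lactone Series

The source may report more compounds than this note shows. Statements on the series, on what has been measured and on what is new or still open speak of the compounds shown alone.

Compound 1 `CC(C)(C)c1cn(C[C@H](O)[C@H]2OC(=O)C(OCc3ccccc3)=C2OCc2ccccc2)nn1`: 29200 nM
Compound 2 `O=C1O[C@H]([C@@H](O)Cn2cc(-c3cc(F)cc(F)c3)nn2)C(OCc2ccccc2)=C1OCc1ccccc1`: 11600 nM
Compound 3 `COc1ccc(-c2cn(C[C@H](O)[C@H]3OC(=O)C(OCc4ccccc4)=C3OCc3ccccc3)nn2)cc1`: 46400 nM

Three compounds share one core and differ only in the group carried on the triazole. In a functional assay on HepG2 cells (Homo sapiens) for antiproliferative activity, read by MTT assay, with a stated time of 72 h (on this read-out higher numbers stand for weaker inhibition and lower numbers for stronger inhibition), compound 1 gives 29200 nM, compound 2 gives 11600 nM and compound 3 gives 46400 nM. Compound 3 stands highest of the three numbers: there is a 1.6-fold higher number from compound 1 to compound 3 (0.20 log units; within the scatter), and there is a 4.0-fold higher number from compound 2 to compound 3 (0.60 log units; beyond the scatter), while a 2.5-fold lower number from compound 1 to compound 2 (0.40 log units; beyond the scatter).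

Compound 4 `Cc1ccc(-c2cn(C[C@H](O)[C@H]3OC(=O)C(OCc4ccccc4)=C3OCc3ccccc3)nn2)cc1` differs from compound 3 in one place: methyl in place of methoxy on an aromatic carbon. Going by the values given here, no measured pair exchanges methoxy for methyl, so nothing bears on this change directly. The steps that come nearest are those replacing the whole group on this aromatic carbon, and of these the exchange of tert-butyl for 4-methoxyphenyl stayed within the scatter, whereas the fluorinated ring moved the number modestly. A small change, likely within the scatter, is therefore expected in this assay, with a slight lean toward a lower number, as the expected step of a 1.3-fold lower number from compound 3 to compound 4 (0.12 log units; within the scatter) shows. Compound 4 is estimated at 35000 nM, between 15000 nM and 80000 nM.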

Compound 4, half-maximal inhibitory concentration: 8770 nM
Compound 4: the middle estimate sits 4.0-fold (0.60 log units) above what was measured; measured number outside the range, below it.
By their numbers in this assay, from the lowest: compounds 4 and 2 (each within the scatter of the next); then compounds 1 and 3 (each within the scatter of the next).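

In this assay, going by these compounds alone, the earlier steps replaced the whole group on the triazole, but this result shows that a small exchange further out on the ring, methyl in place of methoxy para to a large group, can by itself give a 5.3-fold lower number from compound 3 to compound 4 (0.72 log units; beyond the scatter). The 4-methylphenyl group also separates from tert-butyl, with a 3.3-fold lower number from compound 1 to compound 4 (0.52 log units; beyond the scatter), whereas the 4-methoxyphenyl group did not, and it stays level with the 3,5-difluorophenyl ring, with a 1.3-fold lower number from compound 2 to compound 4 (0.12 log units; within the scatter). Nothing at hand explains why this single exchange moves the number.

As far as these compounds go, whether an ethyl, a hydroxyl or an amine on the same aromatic carbon would sit with methyl or with methoxy remains open. So does whether the methyl-for-methoxy step would hold on a ring that also carries fluorine.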